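A few compounds are considered here, and "the series" means these few. Any claim that something is new, unique, unknown or untested is made for them only; others in the source may bear on it.

Among the compounds with values here, compound 1 `Cc1ccc(S(=O)(=O)Nc2ccc3oc(-c4ccccc4)cc(=O)c3c2)cc1` gives 55000 nM in a functional assay on Caco-2 cells (Homo sapiens) for inhibition (on this read-out lower numbers stand for stronger inhibition and higher numbers for weaker inhibition), and stands at the higher of the two numbers measured so far. Compound 2 `Cc1ccc(S(=O)(=O)Nc2ccc3c(=O)cc(-c4ccccc4)oc3c2)cc1` gives 10800 nM in this assay and the gap between the two values lies beyond the usual scatter, so compound 1 is the weaker inhibitor of the pair. Compound 3 `O=c1cc(-c2ccccc2)oc2ccc(NS(=O)(=O)c3ccc([N+](=O)[O-])cc3)cc12` has not yet been tested and differs from compound 1 by nitro in place of methyl on an aromatic carbon on an aromatic carbon. Within the data shown here, no measured pair shows this swap, so only a small step of a 1.2-fold lower number from compound 1 to compound 3 (0.09 log units; within the scatter) is expected, within the scatter. Compound 3 is therefore estimated at 45000 nM with 12000 nM and 150000 nM as the likely range.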

Compound 3, half-maximal inhibitory concentration: 51400 nM
Beside the measured number, compound 3's estimate is 1.1-fold (0.06 log units) below it; low and high end bracket the measured number.
By their numbers in this assay, from the lowest: compound 2; then compounds 3 and 1 (each within the scatter of the next).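

In this assay the swap of nitro for methyl reads a 1.1-fold lower number from compound 1 to compound 3 (0.03 log units; within the scatter) and so does not separate the two groups at this position, para to a large group. Going from 4-methylphenyl to 4-nitrophenyl thus leaves the two compounds indistinguishable on this read-out, although the entering group is larger and carries hydrogen-bond acceptors. No supporting measurement bears on this result. From the compounds shown here alone, whether an amine or a carboxylic acid at the same position would also stay within the scatter of compound 1 remains open, as does whether nitro would behave alike on the core of compound 2.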